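The compounds below may be only part of what the source reports. "The series", "measured", "known", "first", "only" and "open" are said of these compounds alone.

Compound 1 `Nc1nc2[nH]c(CCCCCCC(=O)N[C@@H](CCC(=O)O)C(=O)O)cc2c(=O)[nH]1`: > 1000 nM
Compound 2 `Nc1nc2[nH]c(CCCCCCCCC(=O)N[C@@H](CCC(=O)O)C(=O)O)cc2c(=O)[nH]1`: > 1000 nM

Neither entry is an exact number; each is a limit of the assay. In a functional assay on R2 cells (Cricetulus griseus) for inhibition, with R2 (Homo sapiens) as the target, read by CellTiter-Blue, with a stated time of 96 h (a higher number here means a weaker inhibitor, a lower number a stronger inhibitor), compound 2 gives > 1000 nM, which is a limit. Compound 1 shares that position, so the evidence so far is the limit of > 1000 nM in this assay, at which 2 of the 2 values shown sit. Among the compounds with values here, no measured step is available to show how large a structural change might be.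

Compound 3 `Nc1nc2[nH]c(CCCCCCCCC(=O)O)cc2c(=O)[nH]1` differs from compound 2 at one place, with hydroxy in place of (1,3-dicarboxypropyl)amino on a carbonyl carbon.

With compound 2 at > 1000 nM, a clear gain in this assay is not expected. The expected change is a step that the limit leaves unreadable from compound 2 to compound 3, towards weaker inhibition if it can be read at all. The assay will most likely report only a limit again. For compound 3 the estimate is 3000 nM, with an expected range of 1000 nM to 10000 nM.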

Compound 3, half-maximal inhibitory concentration: > 1000 nM
Compound 3 ended at the assay's limit (the forecaster's own chance of this, stated with the estimate: 90%); the middle value is on the limit's open side.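

Within the data shown here, compound 2 and compound 3 each end at a limit of the assay rather than at an exact number, so no step between them can be read. Still open is how strongly each compound shown inhibits in this assay and whether any structural change shifts that: the limit of > 1000 nM in this assay, at which 3 of the 3 values shown sit.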